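Compound 2 to Compound 3: One Group Exchanged

A few compounds are considered here, and "the series" means these few. Any claim that something is new, unique, unknown or untested is made for them only; others in the source may bear on it.

Compound 1, `COc1cc2c(Oc3ccc(NC(=O)N/N=C/c4ccc(C(F)(F)F)cc4)cc3F)ccnc2cc1OCCCN1CCCC1`, gives 790 nM.
Compound 2, `COc1cc2c(Oc3ccc(NC(=O)N/N=C/c4ccc([N+](=O)[O-])cc4)cc3F)ccnc2cc1OCCCN1CCC(C)CC1`, gives 380 nM.

Both numbers come from a functional assay on A549 cells (Homo sapiens) for cytotoxicity, read by MTT assay, with a stated time of 72 h; on this read-out lower numbers stand for stronger inhibition and higher numbers for weaker inhibition. Of the two, compound 2 stands lower, and the gap to compound 1 lies beyond the usual scatter. For the measured compounds named here, the two compounds differ in two places at once, the group on the outer aromatic ring and the ring at the end of the chain, so no single step between them can be read off.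

Compound 3, `COc1cc2c(Oc3ccc(NC(=O)N/N=C/c4ccc(C(F)(F)F)cc4)cc3F)ccnc2cc1OCCCN1CCC(C)CC1`, keeps the chain end of compound 2 and changes only the outer ring: trifluoromethyl in place of nitro on an aromatic carbon. Compound 1 carries the same trifluoromethyl group, but with a different chain end, so it cannot settle how large this one change is. With that open, the estimate for compound 3 is a modest step of a 1.6-fold higher number from compound 2 to compound 3 (0.20 log units; within the scatter), pointing back toward compound 1 but staying short of it. Compound 3 is expected to give about 600 nM, within a range from 250 nM to 1500 nM.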

Compound 3, half-maximal inhibitory concentration: 650 nM
Compound 3: the middle estimate sits 1.1-fold (0.03 log units) below what was measured; the measured number falls inside the stated range.
By their numbers in this assay, from the lowest: compounds 2, 3 and 1 (each within the scatter of the next, the first and the last beyond it).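

In this assay, for the compounds shown here, compound 3 lets the two differences between the earlier compounds be read one at a time. Exchanging nitro for trifluoromethyl on the aromatic carbon, para to a large group, gives a 1.7-fold higher number from compound 2 to compound 3 (0.23 log units; within the scatter), while exchanging pyrrolidin-1-yl for 4-methylpiperidin-1-yl at the end of the chain gives a 1.2-fold lower number from compound 1 to compound 3 (0.08 log units; within the scatter), with the trifluoromethyl group held constant. Taken alone, neither exchange moves the number beyond the usual scatter, something the earlier pair, which differs in two places at once, could not show.

No measurement is available that would explain either step. From the compounds shown here alone, it also remains open how a nitrile or a methoxy group would read on that aromatic carbon, and how an open-chain amine such as dimethylamino or a morpholine ring would read at the end of the chain.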